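This account rests on a few compounds, and the source may have more. Where it says the series, first, only, none or still open, it means among the compounds named here.

Measured compounds:
compound 1, `Cc1nn(C)c(Oc2ccccc2)c1/C=N/OCc1ccc(C(F)(F)F)cc1`, giving 34.7% in a functional assay on A549 cells (Homo sapiens) for antiproliferative activity, tested at 1 uM; a higher number here means more inhibition at the concentration tested (going by the name of the read-out), a lower number less inhibition;
compound 2, `Cc1nn(C)c(Oc2ccc(Cl)cc2)c1/C=N/OCc1ccc(C(F)(F)F)cc1`, giving 50.9%;
compound 3, `Cc1nn(C)c(Oc2ccccc2)c1/C=N/OCc1cccc(-c2ccccc2)c1C`, giving 5%.

Compound 1 stands second highest of the three. Compound 2 lies above it by a number 16.2 percentage points higher from compound 1 to compound 2 (beyond the scatter), a step made by putting chloro in place of hydrogen on an aromatic carbon of the phenoxy part of the shared core. Compound 3, which carries a quite different group on the benzyl side, lies far lower, and this gap is beyond the scatter.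

Compound 4, `Cc1nn(C)c(Oc2ccccc2)c1/C=N/OCc1ccc([N+](=O)[O-])cc1`, differs from compound 1 by nitro in place of trifluoromethyl on an aromatic carbon, on the aromatic carbon para to a large group. Going by the values given here, no measured step exchanges one small substituent on this ring for another; the only step on record, from compound 1 to compound 2, concerns the other ring, and compound 3 changes the benzyl part wholesale. There is therefore nothing that points firmly in either direction. The expected step is estimated as a number 1.7 percentage points lower from compound 1 to compound 4 (within the scatter), that is no change beyond the scatter. Compound 4 is thus estimated at 33%, between 15% and 55%.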

Compound 4, a percentage reported as inhibition, at one concentration (the size of the read-out at that concentration, not a potency): 39.4%
For compound 4 the middle estimate is 6.4 percentage points below the measured one, and the stated range covers the measured number.
By their numbers in this assay, from the lowest: compound 3; then compounds 1 and 4 (each within the scatter of the next); then compound 2.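

Going by these compounds alone, putting nitro in place of trifluoromethyl, on the aromatic carbon para to a large group, gives in this assay a number 4.7 percentage points higher from compound 1 to compound 4 (within the scatter) and is the first measured change on this ring with the rest of the molecule held fixed. Here, a group with no hydrogen-bond acceptors can give way to one counted with two without a change beyond the scatter, though this rests on a single pair of compounds. Nothing measured here offers an explanation for this result.

On these data alone, whether an amine, a carboxylic acid or a simple methyl on this same carbon would also leave the inhibition unchanged remains open. So does whether nitro would behave the same way alongside the chloro of compound 2.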